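The source may hold more compounds than are shown below. What is called first, only, known or untested is meant among the compounds shown, and "the series" means these compounds.

Measured compounds:
Compound 1, `CC1(C)Oc2ccc(C#N)cc2[C@H](Nc2ccccc2)[C@H]1O`, 1200 nM
Compound 2, `CCOC(=O)CCN(c1ccccc1)[C@H]1c2cc(C#N)ccc2OC(C)(C)[C@@H]1O`, 54000 nM
Compound 3, `CCOC(=O)CN(c1ccc(F)cc1)[C@H]1c2cc(C#N)ccc2OC(C)(C)[C@@H]1O`, > 30000 nM

In a functional assay (aorta) with Rattus norvegicus as the target (on this read-out lower numbers stand for stronger inhibition and higher numbers for weaker inhibition), compound 3 gives only a limit of the assay, > 30000 nM. That limit is the one described by the limit of > 30000 nM in this assay, at which 1 of the 3 values shown sits, so no number places compound 3 against the other two. Among the compounds with values here, compound 1 gives 1200 nM and compound 2 gives 54000 nM; the single measured step, a 45-fold higher number from compound 1 to compound 2 (1.65 log units; beyond the scatter), concerns a different change and does not bear on the step to compound 4. Compound 4, `CCOC(=O)CN(c1nc(C)cs1)[C@H]1c2cc(C#N)ccc2OC(C)(C)[C@@H]1O`, differs from compound 3 by 4-methyl-1,3-thiazol-2-yl in place of 4-fluorophenyl on an amine nitrogen. Within the data shown here, no measured step concerns this exchange, so no direction beyond the scatter is expected. Compound 4 is expected to give 30000 nM, in a range from 5000 nM to 100000 nM. The expected step is a number no higher from compound 3 to compound 4 (the limit leaves the size open).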

Compound 4, half-maximal inhibitory concentration: 84000 nM
For compound 4 the middle estimate is 2.8-fold (0.45 log units) below the measured one, within the range that was stated.
By their numbers in this assay, from the lowest: compound 1; then compounds 2 and 4 (each within the scatter of the next).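

No step can be read from compound 3 to compound 4, because the value of compound 3 is only a limit: the limit of > 30000 nM in this assay, at which 1 of the 4 values shown sits.

The compounds shown leave open how 4-methyl-1,3-thiazol-2-yl and 4-fluorophenyl on an amine nitrogen compare in size of effect.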